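This account rests on a few compounds, and the source may have more. Where it says the series, first, only, none or still open, it means among the compounds named here.

Among the measured compounds shown here, in an ADME assay on brain (Rattus norvegicus) for metabolic stability (a higher number here means that the compound lasts longer, a lower number that the compound disappears faster), compound 1 `OC[C@@H]1CC[C@H](n2cnc3c(F)ncnc32)O1` gives 0.00767 h and compound 2 `OC[C@@H]1CC[C@H](n2cnc3c(Cl)ncnc32)O1` gives 0.317 h as the higher of the two numbers so far. The change from compound 2 to compound 3 `OC[C@@H]1CC[C@H](n2cnc3c(Br)ncnc32)O1` is bromo in place of chloro on an aromatic carbon and amounts to bromo in place of chloro on an aromatic carbon. For the measured compounds named here, only one measured step bears on it (a 41-fold higher number from compound 1 to compound 2 (1.62 log units; beyond the scatter)) with chloro in place of fluoro on the same aromatic carbon. That step was large and upward, yet a single step sets no trend, and nothing measured shows whether it carries over from chloro to bromo. No step beyond the scatter is therefore expected in this assay and no firm direction. The estimated step is a 1.3-fold lower number from compound 2 to compound 3 (0.10 log units; within the scatter) on this reading. For compound 3 the expected half-life is 0.25 h with an estimated range from 0.08 h to 0.8 h in repeated measurements.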

Compound 3, half-life: 0.333 h
The estimate for compound 3 lay 1.3-fold (0.12 log units) below the measured number, and the stated range covers the measured number.
By their numbers in this assay, from the lowest: compound 1; then compounds 2 and 3 (each within the scatter of the next).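

In this assay, the large rise on replacing fluoro with chloro does not continue from chloro to bromo: a 1.1-fold higher number from compound 2 to compound 3 (0.02 log units; within the scatter), while a 43-fold higher number from compound 1 to compound 3 (1.64 log units; beyond the scatter). On this aromatic carbon of the shared core, fluoro therefore stands apart from chloro and bromo, which cannot be separated in this assay. Nothing available explains this separation.

As far as these compounds go, it remains open whether iodo, an amine, a methoxy group or a nitrile at this place would group with chloro and bromo, group with fluoro or fall elsewhere. From the compounds shown here alone, it is also open whether the separation between fluoro and the other two halogens would persist with a change elsewhere on the shared core.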